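Swapping Methoxy for Bromo on a Growth Inhibitor

The source may report more compounds than this note shows. Statements on the series, on what has been measured and on what is new or still open speak of the compounds shown alone.

In a functional assay on PC-3 cells (Homo sapiens) for inhibition, read by sulforhodamine B assay (on this read-out lower numbers stand for stronger inhibition of growth and higher numbers for weaker inhibition of growth), compound 1 `COc1ccc(CN2CCC=C(CCC(=O)NO)C2=O)cc1` gives 7080 nM as the highest of three measured numbers. Compound 2 `O=C(CCC1=CCCN(CCCc2ccc(-c3ccccc3)cc2)C1=O)NO` gives 3230 nM in this assay and compound 3 `O=C(CCC1=CCCN(CCCCc2cccc3ccccc23)C1=O)NO` gives 1690 nM there, both lower than compound 1 by more than the usual scatter. Compound 4 `O=C(CCC1=CCCN(Cc2ccc(Br)cc2)C1=O)NO` has not been measured yet. It matches compound 1 except for bromo in place of methoxy on an aromatic carbon, para to a large group (bromo in place of methoxy on an aromatic carbon). Among the measured compounds shown here, no measured pair shows this swap alone, so the evidence is thin. Only a small expected step of a 1.4-fold lower number from compound 1 to compound 4 (0.15 log units; within the scatter) toward a lower number is estimated in this assay and none beyond the scatter. For compound 4 the estimated value is 5000 nM (expected range from 2000 nM to 12000 nM).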

Compound 4, concentration for 50% growth inhibition: 3150 nM
Compound 4: middle estimate off by 1.6-fold (0.20 log units), on the high side; the measured number falls inside the stated range.
By their numbers in this assay, from the lowest: compounds 3, 4 and 2 (each within the scatter of the next); then compound 1.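

In this assay, putting bromo in place of methoxy on the aromatic carbon gives a 2.2-fold lower number from compound 1 to compound 4 (0.35 log units; beyond the scatter) and the rest of the molecule stays the same. Among the compounds shown here, this is the first direct evidence that the group at this position alone can change growth inhibition, although the step is modest and rests on one pair. No measurement here offers a reason for the step. On these data alone, whether fluoro, chloro, an amine or a carboxylic acid on this carbon would give a lower or higher number remains open. So does whether the same swap would work alike in compounds with a longer chain, such as compound 3.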